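The compounds below may be only part of what the source reports. "The series", "measured", "known", "first", "only" and "open" are said of these compounds alone.

Values measured in a functional assay on COLO 205 cells (Homo sapiens) for antiproliferative activity (on this read-out lower numbers stand for stronger inhibition of growth and higher numbers for weaker inhibition of growth), for the three tested compounds:

Compound 1 `COCCCCCCCCCCC/C=C1\CC(CO)(COC(=O)C(C)(C)C)OC1=O` gives 0.541 ug/mL
Compound 2 `COC(=O)CCCCCCCCCCCCCC/C=C1\CC(CO)(COC(=O)C(C)(C)C)OC1=O` gives 3.86 ug/mL
Compound 3 `CCCCCCCCC(O)CCCCCC/C=C1\CC(CO)(COC(=O)C(C)(C)C)OC1=O` gives 8.91 ug/mL

Compound 3 stands at the top of these numbers, and its 8.91 ug/mL is the highest of the three. Compound 4 `CCCCCOCCCCCCC/C=C1\CC(CO)(COC(=O)C(C)(C)C)OC1=O` has not yet been measured. It differs from compound 3 as follows: (pentyloxy)methyl in place of 1-hydroxynonyl on a saturated chain carbon, six bonds along the chain from a double-bonded chain carbon with (pentyloxy)methyl in place of 1-hydroxynonyl on a saturated chain carbon, six bonds along the chain from a double-bonded chain carbon.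

The closest evidence is the large step of a 16-fold higher number from compound 1 to compound 3 (1.22 log units; beyond the scatter) at that same place, where 1-hydroxynonyl stands in place of 5-methoxypentyl. Compound 1 has no hydroxy group on its chain and gives 0.541 ug/mL in this assay as the lowest number, and compound 4 has none either, so a lower number than that of compound 3 is expected. The modest step of a 7.1-fold higher number from compound 1 to compound 2 (0.85 log units; beyond the scatter) is a caution, as it comes with a chain that also has no hydroxy group. A full return to the level of compound 1 is therefore not expected, and three compounds support no firm rule. The expected change is a 5.9-fold lower number from compound 3 to compound 4 (0.77 log units; beyond the scatter) in the direction of stronger inhibition of growth. The estimate for compound 4 is 1.5 ug/mL with an expected range from 0.4 ug/mL to 6 ug/mL in this read-out.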

Compound 4, concentration for 50% growth inhibition: 0.491 ug/mL
Beside the measured number, compound 4's estimate is 3.1-fold (0.49 log units) above it; low and high end bracket the measured number.
By their numbers in this assay, from the lowest: compounds 4 and 1 (each within the scatter of the next); then compound 2; then compound 3.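

In this assay, (pentyloxy)methyl in place of 1-hydroxynonyl gives an 18-fold lower number from compound 3 to compound 4 (1.26 log units; beyond the scatter), which shows that this place on the chain, six bonds along from a double-bonded chain carbon, can carry a change of large size in either direction. The pentyloxy chain also proves interchangeable with the chain of compound 1 in this read-out, with a 1.1-fold lower number from compound 1 to compound 4 (0.04 log units; within the scatter), so two chains with their ether oxygen at different places along them give the same level of growth inhibition. Lack of a hydroxy group alone does not set that level, since compound 2 goes against it: its chain has no hydroxy group either, and pentyloxy in place of 7-(methoxycarbonyl)heptyl gives a 7.9-fold lower number from compound 2 to compound 4 (0.90 log units; beyond the scatter).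

The compounds shown leave open whether the large step from compound 3 follows the hydroxy group or the size of the chain, as 1-hydroxynonyl and (pentyloxy)methyl differ in both. From the compounds shown here alone, it is also open how an amine or a carboxylic acid at the chain end, or a longer chain with an ether oxygen, would compare with compound 4. Nothing available here accounts for these differences.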